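Series notes: trifluoromethyl analogue of compound 2

A few compounds are considered here, and "the series" means these few. Any claim that something is new, unique, unknown or untested is made for them only; others in the source may bear on it.

Measured values in a functional assay on A-375 cells (Homo sapiens) for antiproliferative activity, read by MTT assay, with a stated time of 24 h, tested at 0.02 ug/mL; on this read-out higher numbers stand for a stronger effect at the one concentration tested and lower numbers for a weaker effect:

compound 1, `CCc1ccc2nc(C(=O)Nc3c(F)cc(-c4cccc(F)c4)cc3F)c(C)c(O)c2c1`: -0.12%
compound 2, `Cc1c(C(=O)Nc2c(F)cc(-c3cccc(F)c3)cc2F)nc2ccc(OC(F)(F)F)cc2c1O`: -0.35%

Within the data shown here, compound 2 holds the lower of the two numbers, but the only measured step, a number 0.2 percentage points lower from compound 1 to compound 2 (within the scatter), is within the scatter, so the two compounds cannot be told apart on this read-out; both sit at essentially no inhibition at the concentration tested.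

Compound 3, `Cc1c(C(=O)Nc2c(F)cc(-c3cccc(F)c3)cc2F)nc2ccc(C(F)(F)F)cc2c1O`, is the next analogue. Its difference from compound 2 is trifluoromethyl in place of trifluoromethoxy on an aromatic carbon.

Among the measured compounds shown here, the single measured step bears on it only loosely: it changed the group at the same aromatic carbon, ethyl giving way to trifluoromethoxy, and it did not move the number beyond the scatter. For the measured compounds named here, no measured pair covers the exchange of trifluoromethoxy for trifluoromethyl. Going by the values given here, with both measured compounds near zero, and the one step at this position flat, no step beyond the scatter is expected for compound 3 in this assay; the expected step is a number 0.4 percentage points higher from compound 2 to compound 3 (within the scatter).

Compound 3 is therefore estimated at 0%, with a range from -10% to 10%.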

Compound 3, a percentage reported as inhibition, at one concentration (the size of the read-out at that concentration, not a potency): 1.28%
Compound 3: middle estimate off by 1.3 percentage points, on the low side; the range from low to high includes it.
By their numbers in this assay, from the lowest: compounds 2, 1 and 3 (each within the scatter of the next).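

In this assay the series now has three groups on this aromatic carbon: trifluoromethyl in place of trifluoromethoxy gives a number 1.6 percentage points higher from compound 2 to compound 3 (within the scatter) and trifluoromethyl in place of ethyl gives a number 1.4 percentage points higher from compound 1 to compound 3 (within the scatter) as the second reading of the new group. The earlier pair covered only ethyl and trifluoromethoxy, whereas the result now shows that removing the oxygen of trifluoromethoxy also leaves no readable step, and ethyl, trifluoromethoxy and trifluoromethyl cannot be told apart on this read-out, with all three compounds close to no inhibition. Nothing available here accounts for this flat picture.

Open, on these data alone, is whether an amine, a carboxylic acid or a longer chain on this aromatic carbon would move the number beyond the scatter. Also open, as far as these compounds go, is whether these three compounds would separate at another concentration, and whether the near-zero reading belongs to the shared core rather than to the group at this carbon, a question that a read-out at one concentration cannot settle.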